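A few compounds are considered here, and "the series" means these few. Any claim that something is new, unique, unknown or untested is made for them only; others in the source may bear on it.

Compound 3 `Cc1ccc(CN2CCN(CC(=O)Nc3ccc(-c4nc(-c5ccccc5)c(-c5ccccc5)n4C)cc3)CC2)cc1` gives 15.4% in a functional assay on HT-29 cells (Homo sapiens) for cytotoxicity, read by MTT assay, with a stated time of 24 h, tested at 0.64 ug/mL (on this read-out lower numbers stand for a weaker effect and higher numbers for a stronger effect at the one concentration tested), the second highest of the three numbers shown, though within the scatter of both neighbours. Compound 1 `CCN1CCN(CC(=O)Nc2ccc(-c3nc(-c4ccccc4)c(-c4ccccc4)n3C)cc2)CC1` gives 7.4% and compound 2 `Cn1c(-c2ccc(NC(=O)CN3CCN(c4ccccc4)CC3)cc2)nc(-c2ccccc2)c1-c1ccccc1` gives 17.3%; the steps of a number 9.9 percentage points higher from compound 1 to compound 2 (within the scatter), a number 8 percentage points higher from compound 1 to compound 3 (within the scatter) and a number 1.9 percentage points lower from compound 2 to compound 3 (within the scatter) all lie within the scatter. Compound 4 `COc1ccc(CN2CCN(CC(=O)Nc3ccc(-c4nc(-c5ccccc5)c(-c5ccccc5)n4C)cc3)CC2)cc1` differs from compound 3 by methoxy in place of methyl on an aromatic carbon. Going by the values given here, no measured step alters a substituent on this aromatic ring; the nearest comparisons exchange the whole group on the ring amine nitrogen and stayed within the scatter, so a step within the scatter is expected for a number 0.4 percentage points lower from compound 3 to compound 4 (within the scatter). Compound 4 is therefore estimated at 15%, with a range from 7% to 24%.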

Compound 4, a percentage reported as activity, at one concentration (the size of the read-out at that concentration, not a potency): 5.2%
For compound 4 the middle estimate is 9.8 percentage points above the measured one; the measured number lies below the stated range.
By their numbers in this assay, from the lowest: compounds 4, 1, 3 and 2 (each within the scatter of the next, the first and the last beyond it).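

In this assay, going by these compounds alone, this aromatic carbon proves sensitive to a small exchange: methoxy in place of methyl gives a number 10.2 percentage points lower from compound 3 to compound 4 (beyond the scatter) and so provides the first step beyond the scatter. Against the phenyl group on the ring amine nitrogen, 4-methoxybenzyl also gives a step beyond the scatter (a number 12.1 percentage points lower from compound 2 to compound 4 (beyond the scatter)), whereas the comparison with the ethyl compound stays within it (a number 2.2 percentage points lower from compound 1 to compound 4 (within the scatter)). Nothing measured here accounts for the methoxy step. As far as these compounds go, whether chloro or hydroxy on this aromatic carbon would give a number nearer compound 3 or compound 4 remains open. Also open, from the compounds shown here alone, is how methoxy would act on the phenyl group of compound 2.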